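A few compounds are considered here, and "the series" means these few. Any claim that something is new, unique, unknown or untested is made for them only; others in the source may bear on it.

Measured in a functional assay on HepG2 cells (Homo sapiens) for antiproliferative activity, read by MTT assay; on this read-out higher numbers stand for weaker inhibition and lower numbers for stronger inhibition:
Compound 1 `Cc1c(-n2cc(COc3ccc(/C=C/C(=O)c4cc5c(cc4O)OC(C)(C)CC5)cc3)nn2)cccc1[N+](=O)[O-]`: 109000 nM
Compound 2 `CC(=O)c1ccc(-n2cc(COc3ccc(/C=C/C(=O)c4cc5c(cc4O)OC(C)(C)CC5)cc3)nn2)cc1`: "not active" (no number reported)
Compound 3 `Cc1c(-n2cc(COc3ccc(/C=C/C(=O)c4ccc5c(c4O)CCC(C)(C)O5)cc3)nn2)cccc1[N+](=O)[O-]`: 115000 nM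

In this assay compound 3 gives 115000 nM, within the scatter of compound 1 at 109000 nM, while compound 2 gives no number and is reported as "not active" (no number reported). Compound 4 `Cc1ccc(-n2cc(COc3ccc(/C=C/C(=O)c4ccc5c(c4O)CCC(C)(C)O5)cc3)nn2)cc1Br` carries 3-bromo-4-methylphenyl in place of 2-methyl-3-nitrophenyl on an aromatic nitrogen. Going by the values given here, no measured pair shows this change on its own, so no step beyond the scatter is expected, and no direction is favoured. The expected change is a 1.2-fold lower number from compound 3 to compound 4 (0.08 log units; within the scatter). Compound 2 at "not active" (no number reported) shows that a reading without a number remains possible. For compound 4 the estimated value is 95000 nM, with an expected range from 40000 nM to 200000 nM.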

Compound 4, half-maximal inhibitory concentration: 110000 nM
Estimate against measurement, compound 4: 1.2-fold (0.06 log units) below, within the range that was stated.
By their numbers in this assay, from the lowest: compounds 1, 4 and 3 (each within the scatter of the next).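

In this assay, placing 3-bromo-4-methylphenyl instead of 2-methyl-3-nitrophenyl on the aromatic nitrogen gives a 1.0-fold lower number from compound 3 to compound 4 (0.02 log units; within the scatter). This position therefore keeps its reading through a change of both ring substituents, with the nitro group and its 2 hydrogen-bond acceptors gone and bromine in their place. Nothing available accounts for this result. From the compounds shown here alone, whether a phenyl ring bearing an amine or a carboxylic acid would move the number beyond the scatter remains open. So does whether an unsubstituted phenyl ring would read the same.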